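The compounds below may be only part of what the source reports. "The series", "measured", "known", "first", "only" and "open" are said of these compounds alone.

Two related compounds have been tested so far in a functional assay on MCF7 cells (Homo sapiens) for inhibition, read by MTT assay, with a stated time of 72 h; a higher number here means a weaker inhibitor, a lower number a stronger inhibitor. Compound 1 (`C/C1=C\CC[C@@]2(C)O[C@@H]2[C@H]2OC(=O)[C@@H](CN3CCN(C)CC3)[C@@H]2C[C@@H]1O`) gives 22000 nM there, and compound 2 (`C[C@]12O[C@@H]1CC[C@@]1(C)O[C@@H]1[C@H]1OC(=O)[C@@H](CN3CCN(c4ccccc4)CC3)[C@@H]1C[C@H]2O`) gives 59000 nM in the same test. Compound 2 therefore has the higher of the two numbers, which makes it the weaker inhibitor of the pair, and the gap to compound 1 lies beyond the usual scatter. These two compounds differ in more than one place, so their gap cannot be tied to any single feature.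

The next compound, compound 3 (`C[C@]12O[C@@H]1CC[C@@]1(C)O[C@@H]1[C@H]1OC(=O)[C@@H](CN3CCN(c4ccccc4F)CC3)[C@@H]1C[C@H]2O`), changes compound 2 in one place only. The change is fluoro in place of hydrogen on an aromatic carbon on an aromatic carbon, ortho to a large group, so phenyl becomes 2-fluorophenyl. Among the compounds with values here, no measured pair here shows what this swap does, and compound 2 at 59000 nM is the only close reference. A small move toward a lower number is expected (a 1.3-fold lower number from compound 2 to compound 3 (0.12 log units; within the scatter)) and it would stay within the usual scatter. In this assay the estimated value for compound 3 is 45000 nM with an expected range of 18000 nM to 100000 nM for repeated measurements.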

Compound 3, half-maximal inhibitory concentration: 20000 nM
Compound 3: the middle estimate sits 2.3-fold (0.35 log units) above what was measured; low and high end bracket the measured number.
By their numbers in this assay, from the lowest: compounds 3 and 1 (each within the scatter of the next); then compound 2.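

This position on the aromatic ring, ortho to a large group, is not indifferent to substitution: in this assay, putting fluoro in place of a single hydrogen gives a 3.0-fold lower number from compound 2 to compound 3 (0.47 log units; beyond the scatter). Within the data shown here, this is the first change that can be tied to one feature, since the gap between the two earlier compounds spans more than one difference. The step is modest but beyond the usual scatter, even though the swap adds only one heavy atom and no ring, hydrogen-bond donor, hydrogen-bond acceptor or net charge, and no measurement shown here explains why the number falls.

One swap at one position cannot show whether this lower number is specific to fluoro or would also appear with another group in the same place, such as chloro, methyl or methoxy. It also leaves open whether fluoro would give a similar step on another carbon of the aromatic ring, or whether a second fluoro would add to it.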